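A Methyl Group Added to the Aromatic Ring of Compound 3

The source may report more compounds than this note shows. Statements on the series, on what has been measured and on what is new or still open speak of the compounds shown alone.

Compound 3 `O=S(=O)(c1ccc(F)cc1)N1CCCC(Cn2ccnc2)C1` gives 51 nM in an assay on isolated protein for inhibition of Aromatase (Homo sapiens), read by fluorescence; a lower number here means a stronger inhibitor, a higher number a weaker inhibitor. Two close relatives have been measured: compound 1 `O=S(=O)(c1ccc(F)c(F)c1)N1CCCC(Cn2ccnc2)C1` gives 43 nM, and compound 2 `N#Cc1ccc(S(=O)(=O)N2CCCC(Cn3ccnc3)C2)cc1` gives 36 nM. The steps were a 1.2-fold higher number from compound 1 to compound 3 (0.07 log units; within the scatter) and a 1.4-fold higher number from compound 2 to compound 3 (0.15 log units; within the scatter), so all three numbers lie within the usual scatter of one another.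

Compound 4 `Cc1cc(F)ccc1S(=O)(=O)N1CCCC(Cn2ccnc2)C1` differs from compound 3 by methyl in place of hydrogen on an aromatic carbon. For the measured compounds named here, no measured step involves a methyl group, so the measured steps bear on this change only indirectly: both swaps on the same ring stayed within the scatter, so small changes there have so far moved the number little. Compound 4 is therefore expected to show a 1.1-fold higher number from compound 3 to compound 4 (0.03 log units; within the scatter) in this assay, no step beyond the scatter. Compound 4 is estimated at 55 nM, in a range from 25 nM to 120 nM.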

Compound 4, half-maximal inhibitory concentration: 48 nM
Compound 4: the middle estimate sits 1.1-fold (0.06 log units) above what was measured, and the stated range covers the measured number.
By their numbers in this assay, from the lowest: compounds 2, 1, 4 and 3 (each within the scatter of the next).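

Methyl in place of hydrogen, on an aromatic carbon ortho to a large group and meta to the fluoro group, gives a 1.1-fold lower number from compound 3 to compound 4 (0.03 log units; within the scatter) in this assay. So this carbon of the ring takes an added heavy atom with no step beyond the scatter, whereas the earlier steps only exchanged groups on other ring carbons. Still open, on these data alone, is whether a longer chain such as ethyl, or an amine, on this same carbon would also leave the number within the scatter. No measurement here explains why the number stays within the scatter.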